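Hydroxamate stilbenes against HDAC6: a phenol repositioned

The source may hold more compounds than are shown below. What is called first, only, known or untested is meant among the compounds shown, and "the series" means these compounds.

The account begins with two measured compounds. In an assay on isolated protein for inhibition of protein deacetylase HDAC6 (Homo sapiens), read by fluorescence, with a stated time of 15 min (on this read-out lower numbers stand for stronger inhibition and higher numbers for weaker inhibition), compound 1 `O=C(NO)c1ccc(/C=C/c2ccnc(-c3cccc(CO)c3)c2)cc1` gives 34 nM, while compound 2 `O=C(NO)c1ccc(/C=C/c2cccc(-c3cccc(O)c3)c2)cc1` gives 200 nM. Within the data shown here, compound 2 thus stands highest of the two numbers known so far, and its gap to compound 1 lies beyond the usual scatter of repeated measurements. Among the measured compounds shown here, the two compounds differ in more than one place, so no single step between them can be described.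

Compound 3 `O=C(NO)c1ccc(/C=C/c2cccc(-c3cc(F)ccc3O)c2)cc1` is not yet measured. It differs from compound 2 by 5-fluoro-2-hydroxyphenyl in place of 3-hydroxyphenyl on an aromatic carbon. For the measured compounds named here, no measured pair shows the consequence of such a change, so the size of the step is open. The author expects compound 3 to give 250 nM in this assay, within a range from 80 nM to 800 nM. The step from compound 2 to compound 3 is thus estimated as a 1.3-fold higher number from compound 2 to compound 3 (0.10 log units; within the scatter), a change that may well stay within the scatter.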

Compound 3, half-maximal inhibitory concentration: 240 nM
The estimate for compound 3 lay 1.0-fold (0.02 log units) above the measured number; the range from low to high includes it.
By their numbers in this assay, from the lowest: compound 1; then compounds 2 and 3 (each within the scatter of the next).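

Replacing 3-hydroxyphenyl with 5-fluoro-2-hydroxyphenyl on this aromatic carbon gives a 1.2-fold higher number from compound 2 to compound 3 (0.08 log units; within the scatter) in this assay. Among these compounds, this is the first step in the account that can be read at a single place, and it shows that this exchange of one substituted phenyl for another leaves the number within the scatter. The compounds shown offer no measurement that would account for this result.

The exchange alters the hydroxyl's place on the ring and adds a fluorine in one step, so the compounds shown cannot tell whether neither alteration matters or whether their effects offset each other. On these data alone, it also remains open whether an amine or a carboxylic acid on this ring, in place of the hydroxyl, would give a step beyond the scatter.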